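Methoxymethoxy on a flat side-chain series

The source may report more compounds than this note shows. Statements on the series, on what has been measured and on what is new or still open speak of the compounds shown alone.

Three compounds on a shared core differ only at a saturated chain carbon bound to a double-bonded ring carbon. In a functional assay on MCF7 cells (Homo sapiens) for antiproliferative activity, read by MTT assay, with a stated time of 48 h (on this read-out lower numbers stand for stronger inhibition and higher numbers for weaker inhibition), compound 1 `CC(C)=CCC[C@]1(C)/C=C/[C@@H](OC(=O)C=C(C)C)[C@](C)(O)/C=C/C(=O)/C(CCl)=C\C1`, with chloro, gives 610 nM, and compound 2 `CC(C)=CCC[C@]1(C)/C=C/[C@@H](OC(=O)C=C(C)C)[C@](C)(O)/C=C/C(=O)/C(CN(C)C)=C\C1`, with dimethylamino, gives 690 nM. Compound 3 `CC(C)=CCC[C@]1(C)/C=C/[C@@H](OC(=O)C=C(C)C)[C@](C)(O)/C=C/C(=O)/C(CN2CCN(C)CC2)=C\C1`, with 4-methylpiperazin-1-yl, gives 550 nM and stands level with the other two, within the scatter of each.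

The next change leads to compound 4 `COCOC/C1=C/C[C@](C)(CCC=C(C)C)/C=C/[C@@H](OC(=O)C=C(C)C)[C@](C)(O)/C=C/C1=O`: methoxymethoxy in place of 4-methylpiperazin-1-yl on a saturated chain carbon bound to a double-bonded ring carbon. In words, this is methoxymethoxy in place of 4-methylpiperazin-1-yl on a saturated chain carbon bound to a double-bonded ring carbon.

All three measured steps bear on it, since each exchanges a group at this same place: a 1.1-fold higher number from compound 1 to compound 2 (0.05 log units; within the scatter), a 1.1-fold lower number from compound 1 to compound 3 (0.04 log units; within the scatter) and a 1.3-fold lower number from compound 2 to compound 3 (0.10 log units; within the scatter). None of the three compounds carries methoxymethoxy, so the read-across is indirect. Even so, no measured exchange here has moved the number beyond the scatter. In this assay, no step beyond the scatter is therefore expected, and neither direction is favoured. The expected step is a 1.1-fold higher number from compound 3 to compound 4 (0.04 log units; within the scatter). For compound 4 the estimated value is 600 nM, with an expected range of 300 nM to 1200 nM.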

Compound 4, half-maximal inhibitory concentration: 3120 nM
Compound 4: the middle estimate sits 5.2-fold (0.72 log units) below what was measured, and the stated range ends below it.
By their numbers in this assay, from the lowest: compounds 3, 1 and 2 (each within the scatter of the next); then compound 4.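

In this assay, among the compounds shown here, methoxymethoxy is the first group at this place to move the number beyond the scatter (a 5.7-fold higher number from compound 3 to compound 4 (0.75 log units; beyond the scatter)), and the same holds against dimethylamino (a 4.5-fold higher number from compound 2 to compound 4 (0.66 log units; beyond the scatter)) and chloro (a 5.1-fold higher number from compound 1 to compound 4 (0.71 log units; beyond the scatter)). The place is therefore not indifferent to every group: compound 4 is the weakest of the four, while chloro, dimethylamino and 4-methylpiperazin-1-yl remain level with one another. Neither the loss of the ring nor the loss of nitrogen tracks this step on its own, since dimethylamino in compound 2 has no ring and chloro in compound 1 has no nitrogen, yet both stay with compound 3. No measurement is available that would explain the step.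

From the compounds shown here alone, it remains open whether the higher number goes with any oxygen-linked group on this saturated chain carbon or with methoxymethoxy specifically, a question that hydroxy, plain methoxy or a longer ether such as 2-methoxyethoxy would address. Also open, going by these compounds, is how far the tolerance seen with the two amines and chloro extends, for instance to morpholin-4-yl, which keeps a six-membered ring and carries an oxygen, or to a carboxylic acid.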